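The compounds below may be only part of what the source reports. "The series", "measured", "known", "first", "only" and "open" are said of these compounds alone.

Three compounds from this series have been examined in a functional assay on K562 cells (Homo sapiens), read by MTT assay, with a stated time of 72 h; on this read-out lower numbers stand for stronger inhibition and higher numbers for weaker inhibition. Compound 1 `Nc1nc(N)c2c(-c3ccsc3)cn([C@@H]3O[C@H](CO)[C@@H](O)[C@H]3O)c2n1` carries a thiophen-3-yl group on its core. In this assay compound 1 gives only a limit of > 20000 nM, not a measured number. Compound 2 `O=c1[nH]cnc2c1c(-c1cc3ccccc3o1)cn2[C@@H]1O[C@H](CO)[C@@H](O)[C@H]1O` bears a 1-benzofuran-2-yl group instead. For compound 2 this assay also reports no more than the limit of > 20000 nM. Compound 3 `CN(C)c1ncnc2c1c(-c1cc3ccccc3o1)cn2[C@@H]1O[C@H](CO)[C@@H](O)[C@H]1O` keeps the 1-benzofuran-2-yl group on a differently substituted core. In this assay compound 3 again reaches only the limit of > 20000 nM. Compound 2 therefore stands nowhere apart from its companions: every value shown rests at the same limit, as the limit of > 20000 nM in this assay, at which 3 of the 3 values shown sit, records, and no order of potency can be drawn among them.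

Compound 4 `O=c1[nH]cnc2c1c(-c1ccsc1)cn2[C@@H]1O[C@H](CO)[C@@H](O)[C@H]1O` remains to be measured. It differs from compound 2 by thiophen-3-yl in place of 1-benzofuran-2-yl on an aromatic carbon. For the measured compounds named here, no step between measured compounds is available to size this change, yet no shift beyond the usual scatter is expected, because the limit of > 20000 nM in this assay, at which 3 of the 3 values shown sit, already covers compound 1 with the same thiophen-3-yl group. The expected step that the limit leaves unreadable from compound 2 to compound 4 is thus essentially none. Compound 4 is estimated at 30000 nM, with a range from 8000 nM to 100000 nM, and most probably the assay will again report only a limit.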

Compound 4, half-maximal inhibitory concentration: > 20000 nM
Compound 4: a limit, no number; the forecaster's own chance of this, stated with the estimate: 85%; the middle value is on the limit's open side.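

In this assay compound 4 also gives only a limit, so no step can be read between compound 2 and compound 4: the limit of > 20000 nM in this assay, at which 4 of the 4 values shown sit. The compounds shown leave open whether any group on this aromatic carbon, or any change to the core, would give a measured number in this assay.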